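This account rests on a few compounds, and the source may have more. Where it says the series, first, only, none or still open, it means among the compounds named here.

In a functional assay on MCF7 cells (Homo sapiens) for inhibition, read by sulforhodamine B assay (a higher number here means a weaker inhibitor, a lower number a stronger inhibitor), compound 1 (`O=C1C=C(NCc2ccccc2)C(=O)c2c1nc1n2[C@H]2OC[C@@H](O)[C@H]2OC1`) gives > 8000 nM, which is a limit of the assay and not a number. Among the compounds with values here, the only numerical value so far belongs to compound 2 (`Cc1ccc(NC2=CC(=O)c3c(nc4n3[C@H]3OC[C@@H](O)[C@H]3OC4)C2=O)cc1C`), which gives 4950 nM. The next compound to be tested is compound 3 (`CCc1ccc(NC2=CC(=O)c3nc4n(c3C2=O)[C@H]2OC[C@@H](O)[C@H]2OC4)cc1`), which has 4-ethylphenyl in place of benzyl on an amine nitrogen. Within the data shown here, no step between measured compounds is available, so the expectation rests on these two results alone. In this assay, a modest move towards stronger inhibition is expected, with compound 3 landing in the same region as compound 2 at 4950 nM. The expected step is an at least 1.7-fold lower number from compound 1 to compound 3 (0.24 log units; that floor lies within the scatter). Compound 3 is estimated at 4500 nM, with an expected range from 1500 nM to 12000 nM.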

Compound 3, half-maximal inhibitory concentration: 960 nM
For compound 3 the middle estimate is 4.7-fold (0.67 log units) above the measured one; measured number below the stated range.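

Within the data shown here, replacing benzylamino with (4-ethylphenyl)amino on this amine nitrogen gives the first change here with a size that can be bounded in this assay: it brings an at least 8.3-fold lower number from compound 1 to compound 3 (0.92 log units; beyond the scatter). The full size of that step cannot be read because compound 1 stands at a limit of the assay, not at a number: the limit of > 8000 nM in this assay, at which 1 of the 3 values shown sits. Having a phenyl ring directly on the nitrogen does not settle the value alone, as compound 2 gives 4950 nM and compound 3 gives 960 nM.

The compounds shown leave open what an unsubstituted phenyl would give on this nitrogen. They also leave open whether a propyl chain or a methoxy group in place of the ethyl would give a lower or a higher number than compound 3.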